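The source may hold more compounds than are shown below. What is called first, only, known or untested is meant among the compounds shown, and "the series" means these compounds.

Measured so far in a physicochemical assay for solubility, with a stated time of 24 h, at pH 2.2; on this read-out lower numbers stand for lower solubility and higher numbers for higher solubility (both entries are limits, not numbers):
- compound 1 `O=C(NC[C@@H]1[C@H]2CN(C(=O)OCc3cc(Cl)cc(Cl)c3)C[C@@H]12)c1ccc2[nH]c(=O)oc2c1` gives < 1 ug/mL as a limit
- compound 2 `O=C(NC[C@@H]1[C@H]2CN(C(=O)/C=C/c3cc(Cl)cc(Cl)c3)C[C@@H]12)c1ccc2[nH]c(=O)oc2c1` gives < 1 ug/mL as a limit

Within the data shown here, compound 2 therefore stands at a limit and has no numerical value to step from. Compound 3 `O=C(NC[C@@H]1[C@H]2CN(C(=O)CCc3cc(Cl)cc(Cl)c3)C[C@@H]12)c1ccc2[nH]c(=O)oc2c1` carries 2-(3,5-dichlorophenyl)ethyl in place of 2-(3,5-dichlorophenyl)ethenyl on a carbonyl carbon. Among the measured compounds shown here, the one measured step that bears on this change is a step that the two limits leave unreadable from compound 1 to compound 2 and it also alters the group on a carbonyl carbon, yet it offers no size to carry over. Both measured compounds sit at the same limit (the limit of < 1 ug/mL in this assay, at which 2 of the 2 values shown sit) and so the series shows neither a readable size nor a direction. No step beyond the usual scatter is expected in this assay and no direction is expected either. The expected step is a step that the limit leaves unreadable from compound 2 to compound 3 on this estimate. Compound 3 is estimated at 0.8 ug/mL with an expected range from 0.3 ug/mL to 4 ug/mL and a report as a limit is the likelier outcome.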

Compound 3, solubility: < 1 ug/mL
Compound 3: only a limit was reported; the forecaster's own chance of this, stated with the estimate: 70%; the middle value lies beyond the limit too.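

In this assay compound 3 gives < 1 ug/mL, which is a limit. No step can be read among compound 1, compound 2 and compound 3, as all three stand at the same limit: the limit of < 1 ug/mL in this assay, at which 3 of the 3 values shown sit.

The compounds shown leave open what the actual values are and whether the three groups on the carbonyl carbon differ at all in this assay.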